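Aryl replacement of the methyl on the ring amine

This account rests on a few compounds, and the source may have more. Where it says the series, first, only, none or still open, it means among the compounds named here.

Measured compounds in an assay on a cell-free system (plasma) for inhibition of Dipeptidyl peptidase 4 (Rattus norvegicus), read by fluorescence; on this read-out higher numbers stand for weaker inhibition and lower numbers for stronger inhibition:
compound 1 `O=C([C@@H]1C[C@H](N2CCCN(c3ccc([N+](=O)[O-])cc3)CC2)CN1)N1CCSC1`, 2.9 nM
compound 2 `CN1CCN([C@@H]2CN[C@H](C(=O)N3CCSC3)C2)CC1`, 81.1 nM
compound 3 `N#Cc1cccnc1N1CCN([C@@H]2CN[C@H](C(=O)N3CCSC3)C2)CC1`, 1.2 nM

Compound 2 gives the highest number of the three in this assay; compound 1 and compound 3 both sit well below it, each beyond the scatter, with compound 3 the lowest.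

Compound 4 `O=C([C@@H]1C[C@H](N2CCN(c3ccccn3)CC2)CN1)N1CCSC1` is not yet measured. It differs from compound 2 by pyridin-2-yl in place of methyl on an amine nitrogen in a ring. For the measured compounds named here, the one measured step that bears on this is a 68-fold lower number from compound 2 to compound 3 (1.83 log units; beyond the scatter), a large drop that also replaces the methyl on the same ring nitrogen with an aromatic ring, though that ring carries an additional nitrile. Compound 1, which bears a different aryl on a ring amine of a different ring size, likewise sits far below compound 2 on the numbers alone. A step of similar direction and substantial size is therefore expected, possibly somewhat smaller than the step to compound 3 since the nitrile is absent; the expected step is a 20-fold lower number from compound 2 to compound 4 (1.31 log units; beyond the scatter). For compound 4 the estimated value in this assay is 4 nM, with a range from 1.5 nM to 12 nM.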

Compound 4, half-maximal inhibitory concentration: 3.5 nM
The estimate for compound 4 lay 1.1-fold (0.06 log units) above the measured number, within the range that was stated.
By their numbers in this assay, from the lowest: compound 3; then compounds 1 and 4 (each within the scatter of the next); then compound 2.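

In this assay the plain pyridin-2-yl on the amine nitrogen in a ring is already enough for a large step (a 23-fold lower number from compound 2 to compound 4 (1.36 log units; beyond the scatter)), so the large drop seen with compound 3 does not depend on the nitrile. The nitrile still counts, though its step is smaller: hydrogen in place of cyano on the aromatic carbon gives a modest change beyond the scatter (a 2.9-fold higher number from compound 3 to compound 4 (0.46 log units; beyond the scatter)). Nothing measured here accounts for either step.

The compounds shown leave open whether this nitrogen needs an aromatic ring at all, or whether a benzyl or cyclohexyl group would serve as well as pyridin-2-yl. Also open, going by these compounds, is whether a group such as a carboxylic acid, an amide or a chlorine in place of the nitrile would match compound 3.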